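Swapping an aromatic sulfonate for a fluorinated alkyl chain

A few compounds are considered here, and "the series" means these few. Any claim that something is new, unique, unknown or untested is made for them only; others in the source may bear on it.

Of the compounds shown here, two that share the same core have been measured in an assay (strain Sprague-Dawley) for inhibition of Amine oxidase [flavin-containing] A (Rattus norvegicus), read by spectrophotometry, with a stated time of 5 min; on this read-out lower numbers stand for stronger inhibition and higher numbers for weaker inhibition. Compound 1 `CNC(=O)/C=C1/COc2cc(OS(=O)(=O)c3cccc(F)c3)ccc21` is the less potent of the two: in this assay compound 1 gives 41 nM. Compound 2 `CNC(=O)/C=C1/COc2c1ccc(OS(=O)(=O)c1ccccc1)c2C`, in which the sulfonate bears a plain phenyl ring and an extra methyl group sits on the core, gives 9.8 nM, and the gap between these two numbers is beyond the usual scatter. Since compound 2 differs from compound 1 in more than one place, these two numbers say only where each compound stands, not what any single change does.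

Compound 3 `CNC(=O)/C=C1/COc2cc(OS(=O)(=O)CCC(F)(F)F)ccc21` is not yet measured. It differs from compound 1 by 3,3,3-trifluoropropyl in place of 3-fluorophenyl on a sulfonyl sulfur, so the aromatic ring attached to the sulfonyl is traded for a short open chain. For the measured compounds named here, no measured pair shows what such a trade does here. The step of a 2.0-fold higher number from compound 1 to compound 3 (0.29 log units; within the scatter) is therefore an expectation only, leaning toward a somewhat weaker inhibition. For compound 3 the expected value is 80 nM, within a range from 25 nM to 300 nM.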

Compound 3, half-maximal inhibitory concentration: 9.1 nM
The estimate for compound 3 lay 8.8-fold (0.94 log units) above the measured number; measured number outside the range, below it.
By their numbers in this assay, from the lowest: compounds 3 and 2 (each within the scatter of the next); then compound 1.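

On the sulfonyl sulfur, whose other neighbour is an oxygen on an aromatic ring, an open chain can take the place of the aromatic ring without any loss in this assay: 3,3,3-trifluoropropyl in place of 3-fluorophenyl gives a 4.5-fold lower number from compound 1 to compound 3 (0.65 log units; beyond the scatter), a modest improvement. For the compounds shown here, this is the first pair here that differs in only one place, so it is the first result that can be read as the effect of a single change, and it shows that, on this core, a ring on the sulfonyl sulfur is not required for a low number. No measurement shown here explains the improvement.

The swap removes the ring and changes the fluorine count in the same step, leaving open whether the ring's removal, the fluorines or both lie behind the result; a plain propyl chain would help to separate these. On these data alone, how far the chain can vary also remains open, as does whether a longer chain such as 4,4,4-trifluorobutyl, or a chain ending in an amine or a carboxylic acid, would keep this level of inhibition.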